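The compounds below may be only part of what the source reports. "The series", "measured", "known", "first", "only" and "open" are said of these compounds alone.

Measured in an ADME assay on L6 cells (Rattus norvegicus) for cytotoxicity, read by resazurin assay, with a stated time of 70 h; a lower number here means a stronger inhibitor, a higher number a weaker inhibitor:
- compound 1 `CC(=O)Oc1ccc2c(c1)C(C)=CC(C)(C)N2Cc1ccccc1`: 24000 nM
- compound 2 `CC(=O)Oc1ccc2c(c1)C(C)=CC(C)(C)N2Cc1ccc(Cl)cc1`: 22000 nM
- compound 3 `COc1ccc(CN2c3ccc(OC(C)=O)cc3C(C)=CC2(C)C)cc1`: 15000 nM

Compound 3 stands within the scatter of both compound 1 and compound 2, so the three do not separate in this assay. The next step leads to compound 4 `CC(=O)Oc1ccc2c(c1)C(C)=CC(C)(C)N2C`: hydrogen in place of 4-methoxyphenyl on a saturated chain carbon bound to a nitrogen on an aromatic ring in a ring. Among the measured compounds shown here, three measured steps touch the same aromatic ring: a 1.1-fold lower number from compound 1 to compound 2 (0.04 log units; within the scatter), a 1.6-fold lower number from compound 1 to compound 3 (0.20 log units; within the scatter) and a 1.5-fold lower number from compound 2 to compound 3 (0.17 log units; within the scatter). For the measured compounds named here, all are small and within the scatter, but each keeps the ring, and no measured compound lacks it. They therefore give only a weak guide, and a modest move to a higher number is tentatively expected. The expected change is a 3.0-fold higher number from compound 3 to compound 4 (0.48 log units; beyond the scatter). Compound 4 is estimated at 45000 nM, with an expected range of 17000 nM to 130000 nM.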

Compound 4, half-maximal inhibitory concentration: 41000 nM
Compound 4: middle estimate off by 1.1-fold (0.04 log units), on the high side; the range from low to high includes it.
By their numbers in this assay, from the lowest: compounds 3, 2, 1 and 4 (each within the scatter of the next, the first and the last beyond it).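

In this assay, among the compounds shown here, replacing the 4-methoxyphenyl with hydrogen gives a 2.7-fold higher number from compound 3 to compound 4 (0.44 log units; beyond the scatter) as the only step so far to pass beyond the scatter. The same replacement on the other two rings gives a 1.9-fold higher number from compound 2 to compound 4 (0.27 log units; within the scatter) and a 1.7-fold higher number from compound 1 to compound 4 (0.23 log units; within the scatter) and stays within the scatter, so removing the aromatic ring separates only compound 3 from compound 4. No measured evidence accounts for this difference. The compounds shown leave open whether a longer chain or an amine on this saturated chain carbon would read like hydrogen or like the aromatic rings.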